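Notes on the aryl amide series: compound 3 to compound 4

The source may report more compounds than this note shows. Statements on the series, on what has been measured and on what is new or still open speak of the compounds shown alone.

Measured so far in a functional assay on NCI-H460 cells (Homo sapiens) for cytotoxicity, read by MTT assay, with a stated time of 72 h; a higher number here means a weaker inhibitor, a lower number a stronger inhibitor:
- compound 1, `COc1cc2c(Oc3ccc(NC(=O)c4cc(-c5ccccc5C)ccn4)cc3F)ccnc2cc1OCCCN1CCN(C)CC1`, 150 nM
- compound 2, `COc1cc2c(Oc3ccc(NC(=O)c4cc(-c5ccccc5)ccn4)cc3F)ccnc2cc1OCCCN1CCCC1`, 130 nM
- compound 3, `COc1cc2c(Oc3ccc(NC(=O)c4cc(-c5ccc(C)cc5)ccn4)cc3F)ccnc2cc1OCCCN1CCCC1`, 160 nM

Compound 3 gives the highest of the three numbers in this assay, but its gap to compound 1 and to compound 2 lies within the scatter, so no order among the three can be claimed. Among the compounds with values here, the one measured step that touches the aryl group, a 1.2-fold higher number from compound 2 to compound 3 (0.09 log units; within the scatter), is also within the scatter.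

Compound 4, `COc1cc2c(Oc3ccc(NC(=O)c4cc(-c5ccccc5C)ccn4)cc3F)ccnc2cc1OCCCN1CCCC1`, has not been measured. It differs from compound 3 by 2-methylphenyl in place of 4-methylphenyl on an aromatic carbon. Within the data shown here, no measured pair differs in exactly this way. Compound 1 carries the same 2-methylphenyl group as compound 4 but a different amine at the end of the alkoxy chain; in this assay compound 1 gives 150 nM, which sits together with compound 3 within the scatter. Among the measured compounds shown here, since the only aryl step in hand, from compound 2 to compound 3, was within the scatter, and since the methyl-bearing compound 1 is likewise close to compound 3, the expected step in this assay is a 1.1-fold lower number from compound 3 to compound 4 (0.03 log units; within the scatter), that is, no change beyond the scatter. Compound 4 is therefore estimated at 150 nM, with a range of 75 nM to 300 nM.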

Compound 4, half-maximal inhibitory concentration: 420 nM
Compound 4: middle estimate off by 2.8-fold (0.45 log units), on the low side; the measured number lies above the stated range.
By their numbers in this assay, from the lowest: compounds 2, 1 and 3 (each within the scatter of the next); then compound 4.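

Within the aryl group, where the methyl sits now counts in this assay: 2-methylphenyl in place of 4-methylphenyl, on the aromatic carbon opposite the ring nitrogen, gives a 2.6-fold higher number from compound 3 to compound 4 (0.42 log units; beyond the scatter) as the first step beyond the scatter at this place. Methyl in place of hydrogen on the aryl group therefore has no single outcome, since a 1.2-fold higher number from compound 2 to compound 3 (0.09 log units; within the scatter) stays within the scatter for 4-methylphenyl, while a 3.2-fold higher number from compound 2 to compound 4 (0.51 log units; beyond the scatter) goes beyond it for 2-methylphenyl. The amine at the end of the alkoxy chain also counts with 2-methylphenyl in place, as pyrrolidin-1-yl in place of 4-methylpiperazin-1-yl gives a 2.8-fold higher number from compound 1 to compound 4 (0.45 log units; beyond the scatter) and so separates two compounds that share that aryl group.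

The compounds shown leave open whether the amine step holds with phenyl or 4-methylphenyl, and whether 3-methylphenyl, 2-chlorophenyl, 2-methoxyphenyl or a morpholine at the chain end would follow the same course. Nothing in hand accounts for either step beyond the scatter, so the size of these steps stands here without an explanation.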